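The source may report more compounds than this note shows. Statements on the series, on what has been measured and on what is new or still open speak of the compounds shown alone.

Measured so far in a functional assay on SNB-19 cells (Homo sapiens) for cytotoxicity, read by sulforhodamine B assay, with a stated time of 48 h, tested at 100 uM; on this read-out lower numbers stand for a stronger effect and higher numbers for a weaker effect at the one concentration tested:
compound 1, `COc1cc(-c2cc(/C=C/C(=O)c3ccc(Cl)c(Cl)c3)[nH]n2)cc(OC)c1OC`: 12%
compound 2, `COc1ccc(C(=O)/C=C/c2cc(-c3cc(OC)c(OC)c(OC)c3)n[nH]2)cc1OC`: -95%
compound 3, `COc1cc(-c2cc(/C=C/C(=O)c3ccc(F)c(F)c3)[nH]n2)cc(OC)c1OC`: 22%

Compound 2 stands lowest of the three numbers in this assay, the strongest effect seen. Its nearest neighbour is compound 1, a number 107 percentage points lower from compound 1 to compound 2 (beyond the scatter); the furthest is compound 3, a number 117 percentage points higher from compound 2 to compound 3 (beyond the scatter). Compound 1 and compound 3 sit close together, a number 10 percentage points higher from compound 1 to compound 3 (within the scatter).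

Compound 4, `COc1cc(C(=O)/C=C/c2cc(-c3cc(OC)c(OC)c(OC)c3)n[nH]2)cc(OC)c1OC`, is the next compound for this assay. It differs from compound 2 in one place: methoxy in place of hydrogen on an aromatic carbon. The result is a trimethoxyphenyl on the carbonyl carbon where compound 2 carries a 3,4-dimethoxyphenyl.

The measured steps all exchange the whole aryl group on the carbonyl carbon, and they show that this position matters a great deal: the two halogenated aryls give small effects, the dimethoxyphenyl a large one. For the measured compounds named here, no measured step adds a single methoxy to an aryl that already carries two, so the size of this step cannot be read from the data. With the dimethoxyphenyl pattern kept and extended, compound 4 is expected to stay near compound 2, with a wide range because nothing directly comparable has been measured. The expected step is a number 25 percentage points higher from compound 2 to compound 4 (beyond the scatter). Compound 4 is estimated at -70%, within a range from -120% to 0%.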

Compound 4, a percentage reported as activity, at one concentration (the size of the read-out at that concentration, not a potency): -98%
Beside the measured number, compound 4's estimate is 28 percentage points above it, and the stated range covers the measured number.
By their numbers in this assay, from the lowest: compounds 4 and 2 (each within the scatter of the next); then compounds 1 and 3 (each within the scatter of the next).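

In this assay, methoxy in place of hydrogen on an aromatic carbon, ortho to a methoxy group and meta to a large group, leaves the read-out unchanged within the scatter: a number 3 percentage points lower from compound 2 to compound 4 (within the scatter). The earlier steps shown here exchanged the whole aryl group on the carbonyl carbon and could move the number widely, as in a number 107 percentage points lower from compound 1 to compound 2 (beyond the scatter), whereas this step shows that an aryl already carrying two methoxy groups keeps its large effect when a further methoxy is added at this place. The information on hand offers no explanation for why this step is so small.

Still open, going by these compounds, is how far this place accepts other groups: a dimethylamino group, a carboxylic acid or a longer chain such as butoxy on the same aromatic carbon could give a different picture from methoxy. Also open, on these data alone, is whether compound 2 and compound 4 would separate at other concentrations, since a single tested concentration gives the size of the effect and not a potency.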